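A few compounds are considered here, and "the series" means these few. Any claim that something is new, unique, unknown or untested is made for them only; others in the source may bear on it.

In a physicochemical assay for solubility, at pH 7.4 (on this read-out higher numbers stand for higher solubility and lower numbers for lower solubility), compound 1 `NS(=O)(=O)c1ccc(S(=O)(=O)CCCO)s1` gives 14600 ug/mL and compound 2 `COCC(=O)OCCCS(=O)(=O)c1ccc(S(N)(=O)=O)s1` gives 970 ug/mL, the lower of the two numbers. Compound 3 `CC(C)COC(=O)OCCCS(=O)(=O)c1ccc(S(N)(=O)=O)s1` has not been measured, and the change from compound 2 is isobutoxy in place of methoxymethyl on a carbonyl carbon. Within the data shown here, only one measured step bears on this: a 15-fold lower number from compound 1 to compound 2 (1.18 log units; beyond the scatter), a large one that brought in the (methoxymethyl)carbonyl group now being altered. It is a different change, so it is only a loose guide, but a further moderate drop is expected, estimated as a 6.5-fold lower number from compound 2 to compound 3 (0.81 log units; beyond the scatter). The expected value for compound 3 is 150 ug/mL, within a range of 40 ug/mL to 550 ug/mL.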

Compound 3, solubility: 80 ug/mL
For compound 3 the middle estimate is 1.9-fold (0.27 log units) above the measured one, within the range that was stated.
By their numbers in this assay, from the lowest: compound 3; then compound 2; then compound 1.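

Keeping the carbonyl group and changing only what sits on its carbon still moves the number in this assay sharply, with a 12-fold lower number from compound 2 to compound 3 (1.08 log units; beyond the scatter). So the identity of this group matters, not just the replacement of the hydrogen on the oxygen. Overall, isobutoxycarbonyl in place of that hydrogen gives a 180-fold lower number from compound 1 to compound 3 (2.26 log units; beyond the scatter). Nothing available explains the drop. Still open, on these data alone, is how a straight butoxy chain would compare with isobutoxy, and whether an amine or a carboxylic acid on the carbonyl carbon would give a higher number.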